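Methoxy to hydroxy: compound 4 against compound 1

The source may report more compounds than this note shows. Statements on the series, on what has been measured and on what is new or still open speak of the compounds shown alone.

Compound 1 `COc1cc(Cl)cc(-c2nn(-c3cccc(NC(=O)Nc4ccc(Cl)c(C(F)(F)F)c4)c3)cc2-c2ccncc2)c1` gives the lowest number of the three in a functional assay on SW-620 cells (Homo sapiens) for inhibition, read by sulforhodamine B assay, with a stated time of 48 h, tested at 100 uM (on this read-out higher numbers stand for a weaker effect at the one concentration tested and lower numbers for a stronger effect), at -58%. Compound 2 `COc1cc(Cl)cc(-c2nn(-c3cccc(NC(=O)c4cccc(C(F)(F)F)c4)c3)cc2-c2ccncc2)c1` reaches 57% and compound 3 `COc1cc(Cl)cc(-c2nn(-c3cccc(NC(=O)Nc4ccc(Cl)c(Cl)c4)c3)cc2-c2ccncc2)c1` reaches 7%. The measured steps all sit on the carbonyl side of the molecule: a number 115 percentage points higher from compound 1 to compound 2 (beyond the scatter) and a number 65 percentage points higher from compound 1 to compound 3 (beyond the scatter), while a number 50 percentage points lower from compound 2 to compound 3 (beyond the scatter). Compound 4 `O=C(Nc1cccc(-n2cc(-c3ccncc3)c(-c3cc(O)cc(Cl)c3)n2)c1)Nc1ccc(Cl)c(C(F)(F)F)c1` alters a different part: hydrogen in place of methyl on an oxygen on an aromatic ring, methoxy to hydroxy on the 3-chloro-5-methoxyphenyl. Among the compounds with values here, no measured step touches that position; the size of the change is not fixed by these data. The carbonyl side is kept as in compound 1, and the expected step is a number 18 percentage points higher from compound 1 to compound 4 (beyond the scatter), within or only a little beyond the scatter. Compound 4 is estimated at -40%, with a range from -85% to 20%.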

Compound 4, a percentage reported as activity, at one concentration (the size of the read-out at that concentration, not a potency): -58%
Compound 4: the middle estimate sits 18 percentage points above what was measured; the measured number falls inside the stated range.
By their numbers in this assay, from the lowest: compounds 1 and 4 (each within the scatter of the next); then compound 3; then compound 2.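

Methoxy to hydroxy on the 3-chloro-5-methoxyphenyl is the first change shown at this position, and in this assay it gives no change at the digits printed from compound 1 to compound 4 (within the scatter) on the read-out. The methyl on this oxygen can therefore give way to hydrogen with no readable shift at the one concentration tested, whereas every step on the carbonyl side lies beyond the scatter. No evidence is available on what lies behind this result.

As far as these compounds go, whether ethoxy or an amine at this position would leave the read-out equally unchanged stays open. Also open, from the compounds shown here alone, is whether the match between these two compounds holds at lower concentrations.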